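A few compounds are considered here, and "the series" means these few. Any claim that something is new, unique, unknown or untested is made for them only; others in the source may bear on it.

Working notes on the series. Within the data shown here, in a functional assay on U-251 cells (Homo sapiens) for inhibition, read by sulforhodamine B assay, with a stated time of 48 h (a higher number here means a weaker inhibitor of growth, a lower number a stronger inhibitor of growth), compound 1 `Cc1ccc(NC(=O)/C=C/c2ccccc2)c(C(N)=O)c1` gives 4130 nM and compound 2 `NC(=O)c1cc(I)ccc1NC(=O)/C=C/c1ccccc1` gives 501 nM, so compound 2 holds the lower of the two numbers so far. Among the measured compounds shown here, the only measured step is an 8.2-fold lower number from compound 1 to compound 2 (0.92 log units; beyond the scatter), for iodo in place of methyl on an aromatic carbon. Compound 3 `NC(=O)c1cc(I)ccc1NC(=O)/C=C/c1ccccc1Cl` keeps the iodo group of compound 2 and adds a new change: chloro in place of hydrogen on an aromatic carbon. In words, this is chloro in place of hydrogen on an aromatic carbon, or phenyl to 2-chlorophenyl. For the measured compounds named here, the measured step concerns a different place in the structure, and no measured step covers this change, so it offers only weak guidance. In this assay only a small step is expected, with no firm direction, and it may stay within the scatter. The expected step is a 1.2-fold lower number from compound 2 to compound 3 (0.08 log units; within the scatter). Compound 3 is estimated at 420 nM, with an expected range of 140 nM to 1300 nM.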

Compound 3, concentration for 50% growth inhibition: 663 nM
Estimate against measurement, compound 3: 1.6-fold (0.20 log units) below; low and high end bracket the measured number.
By their numbers in this assay, from the lowest: compounds 2 and 3 (each within the scatter of the next); then compound 1.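

In this assay, phenyl to 2-chlorophenyl with the iodo group held constant gives a 1.3-fold higher number from compound 2 to compound 3 (0.12 log units; within the scatter) and so does not separate compound 3 from compound 2. A chloro group on this aromatic carbon, ortho to a large group, is therefore tolerated in this one pair, whereas the earlier iodo-for-methyl change at a different place in the structure gave an 8.2-fold lower number from compound 1 to compound 2 (0.92 log units; beyond the scatter) and lay beyond the scatter. No supporting data bear on this result, and the size of the step stays unexplained.

On these data alone, whether a methoxy group or an amine at this same carbon would separate from compound 2 remains open. Also open, as far as these compounds go, is whether the chloro group would behave the same way with the methyl group of compound 1 in place of the iodo group.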